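This account rests on a few compounds, and the source may have more. Where it says the series, first, only, none or still open, it means among the compounds named here.

Measured compounds:
- Compound 1 `O=C(NCc1ccc(S(=O)(=O)c2ccccc2)cc1)c1nc2cnccc2[nH]1` — in a functional assay on A2780 cells (Homo sapiens) for inhibition, read by sulforhodamine B assay, with a stated time of 72 h (a higher number here means a weaker inhibitor, a lower number a stronger inhibitor), compound 1 gives 5400 nM.
- Compound 2 `O=C(NCc1ccc(S(=O)(=O)c2ccccc2)cc1)c1cc(-c2cccnc2)[nH]n1` — compound 2 reaches only the assay limit, > 10000 nM.
- Compound 3 `O=C(NCc1ccc(S(=O)(=O)N2CCCCC2)cc1)c1cc2cccnc2s1` — compound 3 likewise reaches only the assay limit, > 10000 nM.

In this assay, among the compounds with values here, compound 1 is the single compound with a definite number; the other two values shown are limits, and the account of that limit is the limit of > 10000 nM in this assay, at which 2 of the 3 values shown sit. Compound 1 therefore stands alone as the only measured point from which to reason.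

Compound 4 `O=C(NCc1ccc(S(=O)(=O)c2ccccc2)cc1)c1cc2cnccc2[nH]1` keeps the whole sulfone-bearing benzylamide part of compound 1 and changes only the group on the carbonyl carbon: a group of 9 heavy atoms (7 carbon, 2 nitrogen; one five-membered aromatic ring with 1 hetero atom, one six-membered aromatic ring with 1 hetero atom) in place of a group of 9 heavy atoms (6 carbon, 3 nitrogen; one five-membered aromatic ring with 2 hetero atoms, one six-membered aromatic ring with 1 hetero atom), on a carbonyl carbon.

Within the data shown here, no step between measured compounds with a single change is available, so the size of this step has no direct precedent here. The change is small in atom count and keeps both rings aromatic and fused, so the step from compound 1 to compound 4 in this assay is expected to stay within the usual scatter, leaning if anything toward a slight gain. Compound 4 is estimated to give 4000 nM (range 1500 nM to 12000 nM), a step of a 1.4-fold lower number from compound 1 to compound 4 (0.13 log units; within the scatter) that is expected rather than known.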

Compound 4, half-maximal inhibitory concentration: 18 nM
For compound 4 the middle estimate is 220-fold (2.35 log units) above the measured one; measured number below the stated range.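

With the sulfone-bearing benzylamide part held constant, the group on a carbonyl carbon proves to be a highly sensitive place in this assay: replacing the group with a five-membered aromatic ring with 2 hetero atoms by the one with a five-membered aromatic ring with 1 hetero atom gives a 300-fold lower number from compound 1 to compound 4 (2.48 log units; beyond the scatter). Both groups have 9 heavy atoms, so a large step here needs no change in that count. Compound 4 also adds a second definite number to a set otherwise marked by limits: the limit of > 10000 nM in this assay, at which 2 of the 4 values shown sit.

The compounds shown do not tell which property of the two groups carries this step. They also leave open what a methyl group or an amine on the entering group, or a carboxylic acid on the phenyl ring of the sulfone, would do to the measured value of compound 4, 18 nM.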